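Nitro in place of bromo: compound 2 to compound 3

This account rests on a few compounds, and the source may have more. Where it says the series, first, only, none or still open, it means among the compounds named here.

Compound 2 `COc1cc2c(Oc3ccc(NC(=O)c4nn(-c5ccc(Br)cc5)c(=O)c5ccccc45)cc3F)ccnc2cc1OCCCN1CCC(C)CC1` gives 920 nM in a functional assay on HT-29 cells (Homo sapiens) for cytotoxicity, read by MTT assay, with a stated time of 72 h (a higher number here means a weaker inhibitor, a lower number a stronger inhibitor), the lower of the two numbers shown so far. Among the compounds with values here, compound 1 `COc1cc2c(Oc3ccc(NC(=O)c4nn(-c5ccc([N+](=O)[O-])cc5)c(=O)c5ccccc45)cc3F)ccnc2cc1OCCCN1CCCC1` gives 1760 nM in this assay, within the scatter of compound 2; the two differ in more than one place, so no single step links them. Compound 3 `COc1cc2c(Oc3ccc(NC(=O)c4nn(-c5ccc([N+](=O)[O-])cc5)c(=O)c5ccccc45)cc3F)ccnc2cc1OCCCN1CCC(C)CC1` is not yet measured and differs from compound 2 by nitro in place of bromo on an aromatic carbon. Compound 1 also carries the nitro group, and its 1760 nM sits on the higher side. For the step of a 1.5-fold higher number from compound 2 to compound 3 (0.18 log units; within the scatter) a small rise is therefore expected, not clearly beyond the scatter. Compound 3 is estimated at 1400 nM, within 600 nM to 3300 nM.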

Compound 3, half-maximal inhibitory concentration: 2450 nM
Compound 3: middle estimate off by 1.8-fold (0.24 log units), on the low side; measured number inside the range.
By their numbers in this assay, from the lowest: compounds 2, 1 and 3 (each within the scatter of the next, the first and the last beyond it).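

In this assay, within the data shown here, 4-nitrophenyl in place of 4-bromophenyl gives a 2.7-fold higher number from compound 2 to compound 3 (0.43 log units; beyond the scatter) and is the first single change to lie beyond the scatter, though only modestly. With the nitro group held, 4-methylpiperidin-1-yl in place of pyrrolidin-1-yl gives a 1.4-fold higher number from compound 1 to compound 3 (0.14 log units; within the scatter) and so stays within the scatter. Nothing on hand explains the step from bromo to nitro.

Still open, going by these compounds, is how chloro, methoxy or an amine on the same aromatic carbon would read against bromo and nitro. Also open, on these data alone, is whether the step from bromo to nitro holds with pyrrolidin-1-yl on the chain.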